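A few compounds are considered here, and "the series" means these few. Any claim that something is new, unique, unknown or untested is made for them only; others in the source may bear on it.

Measured so far:
Compound 1 `CCc1nc2ccc(Cl)cn2c1C(=O)NCc1ccc(-c2ccccc2Cl)cc1`: 0.218 h
Compound 2 `CCc1nc2cc(Cl)ccn2c1C(=O)NCc1ccc(-c2ccc(C)cc2)cc1`: 0.385 h

In an ADME assay (liver, Mus musculus) for metabolic stability, using microsomes (a lower number here means that the compound disappears faster, a higher number that the compound lasts longer), compound 2 gives 0.385 h and compound 1 gives 0.218 h. These two values lie within the usual scatter of each other, so the data do not set compound 2 apart from compound 1.

Compound 3 `CCc1nc2cc(Cl)ccn2c1C(=O)NCc1ccc(N2CCCCC2)cc1` has not yet been measured. It keeps the core of compound 2 and changes one group: piperidin-1-yl in place of 4-methylphenyl on an aromatic carbon. Piperidin-1-yl stands in place of 4-methylphenyl on an aromatic carbon, para to a large group.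

Compound 1 and compound 2 differ in more than one place, and neither carries piperidin-1-yl, so the measurements offer no direct guide to this change. With so little to go on, only a small downward move is expected, one that would probably stay within the scatter. The estimated step is a 1.4-fold lower number from compound 2 to compound 3 (0.15 log units; within the scatter). For compound 3, the expected half-life in this assay is 0.27 h, with an estimated range from 0.1 h to 0.6 h.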

Compound 3, half-life: 0.0383 h
Estimate against measurement, compound 3: 7.0-fold (0.85 log units) above; measured number outside the range, below it.
By their numbers in this assay, from the lowest: compound 3; then compounds 1 and 2 (each within the scatter of the next).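

In this assay, putting piperidin-1-yl in place of 4-methylphenyl on this aromatic carbon, para to a large group, gives a 10-fold lower number from compound 2 to compound 3 (1.00 log units; beyond the scatter), and compound 3 lasts only 0.0383 h. Among the compounds shown here, the earlier pair differed in more than one place and stayed within the scatter of each other, so this is the first single change that can be read, and it shows that the half-life responds strongly to the group at this position. None of the data shown bear on why the number falls.

On these data alone, one step cannot separate the ring from the nitrogen that joins it to the aromatic carbon, so it remains open whether a cyclohexyl ring, which has no such nitrogen, or a morpholine ring, which adds an oxygen to the piperidine framework, would behave like 4-methylphenyl or like piperidin-1-yl. As far as these compounds go, it also remains open whether the same exchange would have a similar effect on the core of compound 1, which carries its chlorine at a different place.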